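This account rests on a few compounds, and the source may have more. Where it says the series, first, only, none or still open, it means among the compounds named here.

Measured compounds in an assay on CHO-K1 cells for displacement of a labelled ligand from adenosine receptor A1 (Homo sapiens), read by scintillation counting, with a stated time of 60 min; on this read-out lower numbers stand for stronger inhibition and higher numbers for weaker inhibition:
compound 1, `Nc1nc(N/N=C/c2ccc(N3CCCC3)cc2)nc2c1ncn2[C@@H]1O[C@H](CO)[C@@H](O)[C@H]1O`: 5.1 nM
compound 2, `Nc1nc(N/N=C/c2ccc(-c3ccccc3)cc2)nc2c1ncn2[C@@H]1O[C@H](CO)[C@@H](O)[C@H]1O`: 7860 nM

Compound 2 gives the highest of the two numbers in this assay, with compound 1 nearest at a far lower value. Compound 3, `Nc1nc(N/N=C/c2ccc(-n3ccnc3)cc2)nc2c1ncn2[C@@H]1O[C@H](CO)[C@@H](O)[C@H]1O`, carries the change (1H-imidazol-1-yl in place of phenyl on an aromatic carbon). Among the compounds with values here, the only measured step that bears on it is a 1500-fold higher number from compound 1 to compound 2 (3.19 log units; beyond the scatter), and the entering group shares with the group of compound 1 only its nitrogen attachment. A step downward in this assay is therefore expected, smaller than that one. Compound 3 is estimated at 600 nM (range 60 nM to 6000 nM), an expected step of a 13-fold lower number from compound 2 to compound 3 (1.12 log units; beyond the scatter).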

Compound 3, inhibition constant: > 10000 nM
Compound 3: a limit, no number; the forecaster's own chance of this, stated with the estimate: 5%; middle value at least 16-fold (1.22 log units) from the limit.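

In this assay compound 3 gives > 10000 nM as a limit of the assay and not a number. Within the data shown here, with an at least 1.2-fold higher number from compound 2 to compound 3 (0.10 log units; that floor lies within the scatter) as the only reading, no order can be stated between 1H-imidazol-1-yl and phenyl on this aromatic carbon, and the entering group does not bring back the low number of compound 1. The step of an at least 1900-fold higher number from compound 1 to compound 3 (3.29 log units; beyond the scatter) shows that attachment through nitrogen alone does not keep the low number seen with pyrrolidin-1-yl. Still open, as far as these compounds go, is whether piperidin-1-yl, morpholin-4-yl or an open-chain dimethylamino group would keep that low number at this place.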